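The source may hold more compounds than are shown below. What is called first, only, known or untested is meant among the compounds shown, and "the series" means these compounds.

Three compounds share one core and differ only in the group on the ring nitrogen. In a functional assay on B16-F10 cells (Mus musculus) for antiproliferative activity, read by MTT assay, with a stated time of 48 h (on this read-out higher numbers stand for weaker inhibition and lower numbers for stronger inhibition), compound 1 `COc1ccc(-c2cn3cc(C4=CCN(S(=O)(=O)c5ccccc5)CC4)ccc3n2)cc1OC` gives 13200 nM, compound 2 `COc1ccc(-c2cn3cc(C4=CCN(S(=O)(=O)C5CCCC5)CC4)ccc3n2)cc1OC` gives 7690 nM, and compound 3 `COc1ccc(-c2cn3cc(C4=CCN(S(=O)(=O)CCc5ccccc5)CC4)ccc3n2)cc1OC` gives 8080 nM. Compound 3 stands second highest of the three numbers, nearest to compound 2 and furthest from compound 1, with both gaps within the scatter. The steps of a 1.7-fold lower number from compound 1 to compound 2 (0.23 log units; within the scatter), a 1.6-fold lower number from compound 1 to compound 3 (0.21 log units; within the scatter) and a 1.1-fold higher number from compound 2 to compound 3 (0.02 log units; within the scatter) all stay within the scatter. Compound 4 `COc1ccc(-c2cn3cc(C4=CCN(C(=O)c5cccs5)CC4)ccc3n2)cc1OC` carries (thiophen-2-yl)carbonyl in place of phenethylsulfonyl on an amine nitrogen in a ring. Among the measured compounds shown here, no measured step makes this exchange; each only varies the group on a sulfonyl sulfur, and none moved beyond the scatter. The expected step is therefore a 1.0-fold lower number from compound 3 to compound 4 (0.00 log units; within the scatter), none beyond the scatter. Compound 4 is estimated at 8000 nM, between 2500 nM and 25000 nM.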

Compound 4, half-maximal inhibitory concentration: 19500 nM
Compound 4: middle estimate off by 2.4-fold (0.39 log units), on the low side; measured number inside the range.
By their numbers in this assay, from the lowest: compounds 2, 3, 1 and 4 (each within the scatter of the next, the first and the last beyond it).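

In this assay the change on the amine nitrogen in a ring from a sulfonyl group to (thiophen-2-yl)carbonyl gives the first steps at this position beyond the scatter, both modest, with a 2.4-fold higher number from compound 3 to compound 4 (0.38 log units; beyond the scatter) and a 2.5-fold higher number from compound 2 to compound 4 (0.40 log units; beyond the scatter) in the shown series. The exchange for phenylsulfonyl stays within the scatter, with a 1.5-fold higher number from compound 1 to compound 4 (0.17 log units; within the scatter) as its step. No measured evidence accounts for these steps. Compound 4 exchanges the sulfonyl and the ring together, and the compounds shown do not separate the carbonyl from the thiophen-2-yl. On these data alone, how a benzoyl or acetyl group on that nitrogen would read also stays open.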